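Replacing pyridin-2-yl with 2-methoxyphenyl in compound 1

The source may report more compounds than this note shows. Statements on the series, on what has been measured and on what is new or still open speak of the compounds shown alone.

In a functional assay on K562 cells (Homo sapiens) for antiproliferative activity, read by MTT assay (a higher number here means a weaker inhibitor, a lower number a stronger inhibitor), compound 1 `O=C(CCCCCNC(=S)N/N=C(\c1ccccc1)c1ccccn1)NO` gives 2140 nM and compound 2 `C/C(=N\NC(=S)NCCCCCC(=O)NO)c1cccc(C(F)(F)F)c1` gives 1400 nM and these two numbers lie within the scatter of each other, so neither stands apart. Compound 3 `COc1ccccc1/C(=N/NC(=S)NCCCCCC(=O)NO)c1ccccc1` carries 2-methoxyphenyl in place of pyridin-2-yl on a carbon with a double bond to nitrogen. For the measured compounds named here, no measured step isolates this change. Compound 2 has no pyridin-2-yl and still gives 1400 nM as its value, so no step beyond the scatter is expected in this assay for this replacement. The estimated step is a 1.2-fold lower number from compound 1 to compound 3 (0.08 log units; within the scatter) and stays within the scatter. Compound 3 is expected at 1800 nM with an estimated range (700 nM to 4500 nM).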

Compound 3, half-maximal inhibitory concentration: 3560 nM
The estimate for compound 3 lay 2.0-fold (0.30 log units) below the measured number, and the stated range covers the measured number.
By their numbers in this assay, from the lowest: compounds 2, 1 and 3 (each within the scatter of the next, the first and the last beyond it).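

In this assay, for the compounds shown here, putting 2-methoxyphenyl in place of pyridin-2-yl on a carbon with a double bond to nitrogen gives a 1.7-fold higher number from compound 1 to compound 3 (0.22 log units; within the scatter) and thus provides the first direct reading of this change. Losing the pyridine ring nitrogen and gaining the methoxy group together produce no step beyond the scatter, so neither group stands apart here. Nothing at hand explains the result.
From the compounds shown here alone, it remains open whether a ring carrying an amine or a carboxylic acid in this place would move the number beyond the scatter.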